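The source may hold more compounds than are shown below. What is called first, only, known or untested is meant among the compounds shown, and "the series" means these compounds.

Compound 1 `O=C(Nc1ccccc1Br)N[C@@H]1CCN(c2ccc(Br)cn2)C1` and compound 2 `Cc1ccc2c(c1)CCN2CCNC(=O)Nc1ccccc1Br` were both tested in a functional assay for antagonist activity at transient receptor potential cation channel subfamily V member 1 (Rattus norvegicus), read by FLIPR; a higher number here means a more potent compound, by a factor of ten per unit of this negative logarithm, a lower number a less potent compound. Compound 1 gives 7.2, and compound 2 gives 7.3; the two numbers lie within the usual scatter of each other, so neither can be called more potent. Compound 3 `O=C(Nc1ccccc1Br)N[C@@H]1CCN(c2cccc(F)c2)C1` has not yet been measured. It differs from compound 1 by 3-fluorophenyl in place of 5-bromopyridin-2-yl on an amine nitrogen in a ring. For the measured compounds named here, no measured pair shows this kind of change, so there is no step to lean on. The change is expected to move this assay little: a step of a number 0.20 log units lower from compound 1 to compound 3 (within the scatter) is expected, not beyond the scatter. Compound 3 is therefore estimated at 7, with a likely range from 6.3 to 7.7.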

Compound 3, negative logarithm of the antagonist equilibrium constant: 7.8
The estimate for compound 3 lay 0.80 log units below the measured number, outside the stated range (above it).
By their numbers in this assay, from the lowest: compounds 1 and 2 (each within the scatter of the next); then compound 3.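

In this assay, 3-fluorophenyl in place of 5-bromopyridin-2-yl on the amine nitrogen in the ring brings a number 0.60 log units higher from compound 1 to compound 3 (beyond the scatter), so the aromatic group at this position does affect potency. The entering group lacks the ring nitrogen and the bromine and adds fluorine, and this single step cannot separate those differences. Nothing available explains the gain. The compounds shown leave open which of those differences matters, and how a plain phenyl or a 3-methoxyphenyl group would compare at this position.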